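This account rests on a few compounds, and the source may have more. Where it says the series, first, only, none or still open, it means among the compounds named here.

Compound 2, `CCCNC(=S)NS(=O)(=O)c1ccc(-n2nc(C(=O)O)cc2C)cc1`, is measured in a functional assay on the whole organism (blood, strain albino) with Mus musculus as the target, with stated times of 6 days and 4 h, at a dose of 0.4 mmol/kg by the oral route; a lower number here means less inhibition, a higher number more inhibition at the dose given (going by the name of the read-out). In this assay compound 2 gives only the limit of the assay, < 1%, and not a number. Compound 1, `Cc1cc(C(=O)O)nn1-c1ccc(S(=O)(=O)NC(=S)NC2CCCCC2)cc1`, gives 1%. The step of a number no higher from compound 1 to compound 2 (the limit leaves the size open) cannot be sized, because the limit of < 1% in this assay, at which 1 of the 2 values shown sits, leaves it open. Compound 3, `CCNC(=O)NS(=O)(=O)c1ccc(-n2nc(C(=O)O)cc2C)cc1`, differs from compound 2 by a group of 5 heavy atoms (3 carbon, 1 nitrogen, 1 oxygen; no ring) in place of a group of 6 heavy atoms (4 carbon, 1 nitrogen, 1 sulfur; no ring), on a sulfonamide nitrogen. Among the measured compounds shown here, no measured step covers this exact change, and both measured values lie at or near the limit. Compound 3 is therefore expected to stay there, with an expected step of a number no lower from compound 2 to compound 3 (the limit leaves the size open). The estimate for compound 3 is 1%, between 0% and 8%.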

Compound 3, a percentage reported as inhibition, in the whole organism at one dose (the size of the read-out at that dose, not a potency): 0%
The estimate for compound 3 lay 1 percentage points above the measured number, and the stated range covers the measured number.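

Putting ethylcarbamoyl on a sulfonamide nitrogen, in place of the larger sulfur-bearing group of compound 1, gives a number 1 percentage points lower from compound 1 to compound 3 (within the scatter) in this assay. This position therefore now carries a group with oxygen as well as groups with sulfur, and the oxygen-bearing group shows no difference from compound 1 beyond the scatter. Compound 2 has a limit of the assay and not a number, so the steps that involve it cannot be read: the limit of < 1% in this assay, at which 1 of the 3 values shown sits.

From the compounds shown here alone, whether a phenyl ring or a longer chain such as octyl on this nitrogen would give a clearly higher reading stays open. So does the effect of a methyl ester in place of the carboxylic acid.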